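Bromo in place of trifluoromethyl on compound 2

This account rests on a few compounds, and the source may have more. Where it says the series, first, only, none or still open, it means among the compounds named here.

Two compounds have values so far in an ADME assay on L02 cells (Homo sapiens) for cytotoxicity, read by MTT assay, with a stated time of 24 h (on this read-out higher numbers stand for weaker inhibition and lower numbers for stronger inhibition), and they read:

compound 1 (`CN1C/C(=C\c2cccnc2)C(=O)/C(=C/c2ccccc2C(F)(F)F)C1`) 14100 nM
compound 2 (`O=C1/C(=C/c2cccnc2)CN(S(=O)(=O)c2ccc(C(F)(F)F)cc2)C/C1=C\c1ccccc1C(F)(F)F`) 14300 nM

Going by the values given here, on these numbers compound 2 stands level with the only other measured compound. Compound 1 at 14100 nM and compound 2 at 14300 nM lie within the scatter of each other, so neither can be ranked above the other.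

The next compound is compound 3 (`O=C1/C(=C/c2cccnc2)CN(S(=O)(=O)c2ccc(Br)cc2)C/C1=C\c1ccccc1C(F)(F)F`), which differs from compound 2 in one place (bromo in place of trifluoromethyl on an aromatic carbon). It carries bromo in place of trifluoromethyl on an aromatic carbon, para to a large group. Among the compounds with values here, no measured pair in this small set isolates a single change, so the data offer no direct precedent for this swap.

In this assay no step beyond the scatter is expected, and neither direction is favoured. This expectation takes compound 2 at 14300 nM as its starting point, and nothing measured argues for a move away from it. The estimated change is a 1.1-fold lower number from compound 2 to compound 3 (0.04 log units; within the scatter) and is expected to stay within the usual scatter. For compound 3 the expected value is 13000 nM with an estimated range from 6000 nM to 28000 nM in this assay.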

Compound 3, half-maximal inhibitory concentration: 13300 nM
Compound 3: middle estimate off by 1.0-fold (0.01 log units), on the low side, and the stated range covers the measured number.
By their numbers in this assay, from the lowest: compounds 3, 1 and 2 (each within the scatter of the next).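

In this assay, going by these compounds alone, bromo in place of trifluoromethyl on an aromatic carbon, para to a large group, gives a 1.1-fold lower number from compound 2 to compound 3 (0.03 log units; within the scatter), the first comparison in this set that isolates a single change, and it stays within the scatter. The exchange of methyl for (4-bromophenyl)sulfonyl on the amine nitrogen in a ring gives a 1.1-fold lower number from compound 1 to compound 3 (0.03 log units; within the scatter), so this second single-place comparison also stays within the scatter and neither exchange separates the compounds in this assay. Nothing available explains why these readings stay together.

On these data alone, the two exchanges cover only trifluoromethyl and bromo at the aromatic carbon, and only methyl and the (4-bromophenyl)sulfonyl group on the amine nitrogen, so the reach of this flat result remains unknown. As far as these compounds go, whether an amine or a carboxylic acid at that aromatic carbon, or a longer chain on the amine nitrogen, would produce a step beyond the scatter stays open.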